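Swapping a Chlorophenyl Amide for a Methylsulfonylphenyl Amide

The compounds below may be only part of what the source reports. "The series", "measured", "known", "first", "only" and "open" are said of these compounds alone.

Among the measured compounds shown here, compound 2 `O=C(Nc1ccc(Cl)c(-c2nnc3c(Cl)cccn23)c1)c1cccc(Cl)c1` gives 43100 nM in a functional assay on U-251 cells (Homo sapiens) for antiproliferative activity, read by MTT assay, with a stated time of 72 h (a lower number here means a stronger inhibitor, a higher number a weaker inhibitor), the smaller of the two numbers measured so far, while compound 1 `Cc1nc(C(=O)Nc2ccc(Cl)c(-c3nnc4c(Cl)cccn34)c2)cs1` gives 74300 nM in this assay, a gap that stays within the scatter. Compound 3 `CS(=O)(=O)c1ccc(C(=O)Nc2ccc(Cl)c(-c3nnc4c(Cl)cccn34)c2)cc1` differs from compound 2 by 4-(methylsulfonyl)phenyl in place of 3-chlorophenyl on a carbonyl carbon. For the measured compounds named here, the only step measured, a 1.7-fold lower number from compound 1 to compound 2 (0.24 log units; within the scatter), changes the same position with a different group and shows no effect beyond the scatter, so the step of a 1.0-fold higher number from compound 2 to compound 3 (0.02 log units; within the scatter) is expected to be small, with no clear direction. Compound 3 is therefore estimated at 45000 nM, within a range from 15000 nM to 130000 nM.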

Compound 3, half-maximal inhibitory concentration: > 100000 nM
Compound 3: no number, only a limit (the forecaster's own chance of this, stated with the estimate: 20%); at least 2.2-fold (0.34 log units) between middle value and limit.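

The earlier swap on this carbonyl carbon stayed within the scatter, but 4-(methylsulfonyl)phenyl gives an at least 2.3-fold higher number from compound 2 to compound 3 (0.36 log units; beyond the scatter), so the group here can weaken the result in this assay. Against the thiazole, the reading is an at least 1.3-fold higher number from compound 1 to compound 3 (0.12 log units; that floor lies within the scatter), which gives only a floor and no clear separation. The entry for compound 3 is a limit of the assay, not a number: the limit of > 100000 nM in this assay, at which 1 of the 3 values shown sits.

Going by these compounds, how large the true step is stays open. So does whether a phenyl ring carrying an amine or a carboxylic acid on this carbonyl carbon would stay close to compound 2.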